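Cytotoxicity notes: nitrophenyl variant of the pyrazole series

The source may report more compounds than this note shows. Statements on the series, on what has been measured and on what is new or still open speak of the compounds shown alone.

Compound 3 `Cc1ccccc1-c1nn(-c2cccc(C(F)(F)F)c2)cc1CNCCN1CCN(C)CC1` gives 18000 nM in an ADME assay on Huh-7 cells (Homo sapiens) for cytotoxicity; a lower number here means that less compound is tolerated, a higher number that more compound is tolerated. Among the three measured compounds this is the highest number, but only within the scatter: compound 1 `Cc1ccccc1-c1nn(-c2ccc(C(F)(F)F)cc2)cc1CNCCN1CCN(C)CC1` gives 11000 nM in this assay, and compound 2 `Cc1ccccc1-c1nn(-c2ccc(Br)cc2)cc1CNCCN1CCN(C)CC1` gives 9600 nM. The steps between them, a 1.6-fold higher number from compound 1 to compound 3 (0.21 log units; within the scatter), a 1.9-fold higher number from compound 2 to compound 3 (0.27 log units; within the scatter) and a 1.1-fold lower number from compound 1 to compound 2 (0.06 log units; within the scatter), all stay inside the scatter, so swapping the group on the aromatic nitrogen between 4-(trifluoromethyl)phenyl, 4-bromophenyl and 3-(trifluoromethyl)phenyl has not moved the number in a measurable way.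

Compound 4 `Cc1ccccc1-c1nn(-c2ccc([N+](=O)[O-])cc2)cc1CNCCN1CCN(C)CC1` differs from compound 3 by 4-nitrophenyl in place of 3-(trifluoromethyl)phenyl on an aromatic nitrogen. Going by the values given here, no measured step covers a 4-nitrophenyl group; the steps that bear on it are the three changes of the aryl group on the aromatic nitrogen just given, all within the scatter. The step from compound 3 to compound 4 is therefore expected to be a 1.5-fold lower number from compound 3 to compound 4 (0.18 log units; within the scatter), nothing beyond the scatter in either direction. Compound 4 is estimated at 12000 nM in this assay, in a range from 5000 nM to 30000 nM.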

Compound 4, half-maximal cytotoxic concentration: > 20000 nM
Compound 4 was reported as a limit (the forecaster's own chance of this, stated with the estimate: 10%); middle value at least 1.6-fold (0.22 log units) from the limit.
By their numbers in this assay, from the lowest: compounds 2, 1 and 3 (each within the scatter of the next). At a limit, above all of these: compound 4.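

Nitro in place of bromo on an aromatic carbon gives an at least 2.0-fold higher number from compound 2 to compound 4 (0.31 log units; beyond the scatter) and is the first step at this position that clears the scatter. Nitro in place of trifluoromethyl gives an at least 1.8-fold higher number from compound 1 to compound 4 (0.25 log units; that floor lies within the scatter) and 4-nitrophenyl in place of 3-(trifluoromethyl)phenyl gives an at least 1.1-fold higher number from compound 3 to compound 4 (0.04 log units; that floor lies within the scatter) and both of these floors stay within the scatter, so compound 4 is not yet separated from compound 1 or compound 3. The reading for compound 4 is a limit and not a number, so each of these steps is only a floor: the limit of > 20000 nM in this assay, at which 1 of the 4 values shown sits.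

As far as these compounds go, how far the true number of compound 4 lies past its limit remains open. Also open, from the compounds shown here alone, is whether the step to compound 2 is particular to nitro or would also appear with an amine or a carboxylic acid on the same phenyl ring.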